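The source may hold more compounds than are shown below. What is called first, only, known or untested is meant among the compounds shown, and "the series" means these compounds.

Measured so far in a functional assay on DLD-1 cells (Homo sapiens) for inhibition, read by crystal violet staining, with stated times of 72 h and 7 days (on this read-out higher numbers stand for an effect only at larger amounts of compound and lower numbers for an effect already at smaller amounts), for three compounds:
- compound 1 `COc1ccc(S(=O)(=O)Nc2ccc3oc(-c4ccc(NC(=O)c5cccc(C)c5[N+](=O)[O-])cc4)nc3c2)cc1` gives 1600 nM
- compound 2 `COc1ccc(S(=O)(=O)Nc2ccc3oc(-c4ccc(NC(=O)c5ccc(Cl)s5)cc4)nc3c2)cc1` gives 11000 nM
- compound 3 `O=C(Nc1ccc(Sc2nc3ccccc3s2)c(Cl)c1)c1cccc(Br)c1O` gives 11000 nM

Compound 3 reads level with compound 2, and the two share the highest number of the three. Compound 1 lies lower by more than the scatter.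

Compound 4 `COc1c(Br)cccc1C(=O)Nc1ccc(Sc2nc3ccccc3s2)c(Cl)c1` differs from compound 3 in one place: methyl in place of hydrogen on an oxygen on an aromatic ring which reads as hydroxy to methoxy.

Within the data shown here, only one measured step links two compounds that differ in one place. It is a 6.9-fold higher number from compound 1 to compound 2 (0.84 log units; beyond the scatter) with 5-chlorothiophen-2-yl in place of 3-methyl-2-nitrophenyl on a carbonyl carbon. That step belongs to the core of compound 1, not to the core of compound 3, so it offers only a rough size for a single change in this set. Among the measured compounds shown here, no measured pair tests hydroxy to methoxy, and a step of similar size in either direction cannot be excluded.

The working expectation is therefore no shift beyond the scatter, starting from compound 3 at 11000 nM in this assay as the anchor. The estimated step is a 1.2-fold higher number from compound 3 to compound 4 (0.07 log units; within the scatter) and its direction is uncertain. The estimate for compound 4 is 13000 nM with an expected range from 4500 nM to 38000 nM in this read-out.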

Compound 4, half-maximal effective concentration: 10000 nM
Compound 4: middle estimate off by 1.3-fold (0.11 log units), on the high side; measured number inside the range.
By their numbers in this assay, from the lowest: compound 1; then compounds 4, 2 and 3 (each within the scatter of the next).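

In this assay, among these compounds, the change from hydroxy to methoxy gives a 1.1-fold lower number from compound 3 to compound 4 (0.04 log units; within the scatter), the first one-place step to test this position, and it lies within the scatter. On this core, then, the hydrogen on the oxygen on an aromatic ring can give way to a methyl without the read-out leaving the scatter, so the number held by compound 3 does not depend on that hydrogen being present. No supporting data bear on why the read-out stays put, and this single pair gives no account of it.

The compounds shown leave open whether anything larger on that oxygen, such as an ethyl group or a longer chain, or an amine or a carboxylic acid in place of the hydroxy, would shift the number beyond the scatter. They also leave open whether hydroxy to methoxy would be as quiet on the core of compound 1, where a single change elsewhere, a 6.9-fold higher number from compound 1 to compound 2 (0.84 log units; beyond the scatter), does go beyond the scatter.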